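Methoxy for Bromo on the Aryl Piperazine of Compound 2

This account rests on a few compounds, and the source may have more. Where it says the series, first, only, none or still open, it means among the compounds named here.

Three compounds share one core and differ only in the aryl group on the amine nitrogen in the ring. Compound 1 `O=C([C@@H]1C[C@H](N2CCN(c3ccccn3)CC2)CN1)N1CCSC1` gives 3.5 nM in an assay on a cell-free system (plasma) for inhibition of Dipeptidyl peptidase 4 (Rattus norvegicus), read by fluorescence; on this read-out lower numbers stand for stronger inhibition and higher numbers for weaker inhibition; compound 3 `O=C([C@@H]1C[C@H](N2CCN(c3ccc(Cl)c(Cl)c3)CC2)CN1)N1CCSC1` gives 4.2 nM; compound 2 `O=C([C@@H]1C[C@H](N2CCN(c3ccc(Br)cc3)CC2)CN1)N1CCSC1` gives 9 nM, the highest of the three numbers. The steps of a 2.6-fold higher number from compound 1 to compound 2 (0.41 log units; beyond the scatter) and a 2.1-fold lower number from compound 2 to compound 3 (0.33 log units; beyond the scatter) show that exchanging this aryl group moves the numbers only modestly. Compound 4 `COc1ccc(N2CCN([C@@H]3CN[C@H](C(=O)N4CCSC4)C3)CC2)cc1` carries methoxy in place of bromo on an aromatic carbon. Among the measured compounds shown here, no measured step involves methoxy, so the direction is uncertain; a modest step toward the other two compounds is expected. Compound 4 is therefore estimated at 6 nM, range 2.5 nM to 15 nM, meaning a 1.5-fold lower number from compound 2 to compound 4 (0.18 log units; within the scatter).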

Compound 4, half-maximal inhibitory concentration: 16.9 nM
Beside the measured number, compound 4's estimate is 2.8-fold (0.45 log units) below it; the whole stated range lies below it.
By their numbers in this assay, from the lowest: compounds 1 and 3 (each within the scatter of the next); then compounds 2 and 4 (each within the scatter of the next).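

At this position methoxy cannot be told apart from bromo, since the step (a 1.9-fold higher number from compound 2 to compound 4 (0.27 log units; within the scatter)) stays within the scatter. The steps from the other two aryl groups (a 4.0-fold higher number from compound 3 to compound 4 (0.60 log units; beyond the scatter); a 4.8-fold higher number from compound 1 to compound 4 (0.68 log units; beyond the scatter)) lie beyond the scatter but remain modest, so the 4-methoxyphenyl compound groups with the 4-bromophenyl compound rather than with compound 1 or compound 3. No available evidence accounts for these numbers. The compounds shown leave open whether an amine or a carboxylic acid on this aromatic carbon would stay within the same modest span.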